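The compounds below may be only part of what the source reports. "The series", "measured", "known", "first", "only" and "open" are said of these compounds alone.

Compound 1 (`COc1ccc(S(=O)(=O)Nc2ccc(Cl)c3cc[nH]c23)cc1`) measured at 0.92 ug/mL
Compound 2 (`O=S(=O)(Nc1cccc2cc[nH]c12)c1ccc(Cl)cc1`) measured at 6 ug/mL

In a functional assay on KB cells (Homo sapiens) for antiproliferative activity, read by colorimetric assay and MTT assay (a lower number here means a stronger inhibitor, a higher number a weaker inhibitor), compound 2 has the higher of the two numbers, which makes it the weaker inhibitor, and its gap to compound 1 lies beyond the usual scatter. These two compounds differ in more than one place, so their gap cannot be pinned on any single change.

Compound 3 (`O=S(=O)(Nc1ccc(Cl)c2cc[nH]c12)c1ccc(Cl)cc1`) comes from compound 2 by one change, chloro in place of hydrogen on an aromatic carbon, para to a large group (chloro in place of hydrogen on an aromatic carbon). No single change of this kind has been measured yet. Going by the values given here, the only guide is compound 1, which carries a chloro at the same place on the shared core and reads 0.92 ug/mL in this assay despite a different group on its other ring. On this thin evidence, a fall in the number beyond the scatter is expected, and the estimated step is a 4.0-fold lower number from compound 2 to compound 3 (0.60 log units; beyond the scatter) in this assay overall. Compound 3 is estimated at 1.5 ug/mL with an expected range from 0.4 ug/mL to 5 ug/mL for now.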

Compound 3, half-maximal inhibitory concentration: 9.7 ug/mL
Compound 3: the middle estimate sits 6.5-fold (0.81 log units) below what was measured; the measured number lies above the stated range.
By their numbers in this assay, from the lowest: compound 1; then compounds 2 and 3 (each within the scatter of the next).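

In this assay, putting chloro in place of hydrogen on an aromatic carbon, para to a large group, gives a 1.6-fold higher number from compound 2 to compound 3 (0.21 log units; within the scatter), so in this pair, which carries chloro on its other ring, the change at this position makes no difference that can be told from the usual spread of repeat measurements. The step that does stand out lies at the other end of the molecule: chloro in place of methoxy on an aromatic carbon gives an 11-fold higher number from compound 1 to compound 3 (1.02 log units; beyond the scatter), a large step, so among these compounds the low number of compound 1 goes with its methoxy and not with the chloro on the shared core alone. Nothing measured here offers a reason for either step.

As far as these compounds go, whether chloro at this position matters when the other ring carries methoxy stays open, as that question needs a methoxy compound with hydrogen at this place. Also open, from the compounds shown here alone, is how an amine or a carboxylic acid would read at either of these two places in this assay.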